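Bromo to Nitro on Two Quinazoline Anilide Cores

The source may hold more compounds than are shown below. What is called first, only, known or untested is meant among the compounds shown, and "the series" means these compounds.

Compound 1 `O=C(CSc1nc(Nc2ccccc2)c2ccccc2n1)Nc1ccc(Br)cc1` was assayed in a functional assay on MDA-MB-231 cells (Homo sapiens) for inhibition, read by MTT assay, with a stated time of 72 h (on this read-out higher numbers stand for weaker inhibition and lower numbers for stronger inhibition), and compound 1 gave 11500 nM. Replacing its aromatic bromo with nitro, a change of nitro in place of bromo on an aromatic carbon, gave compound 2 `O=C(CSc1nc(Nc2ccccc2)c2ccccc2n1)Nc1ccc([N+](=O)[O-])cc1`, which in this assay gave 16800 nM; the step is a 1.5-fold higher number from compound 1 to compound 2 (0.16 log units; within the scatter).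

Compound 3 `C=CC(=O)Nc1cccc(NC(=O)CSc2nc(Nc3cccc(Br)c3)c3ccccc3n2)c1` carries a different core; the difference between the two cores is not broken down here. In this assay compound 3 gave 19400 nM, which sits close to the values of compound 1 and compound 2.

Compound 4 `C=CC(=O)Nc1cccc(NC(=O)CSc2nc(Nc3cccc([N+](=O)[O-])c3)c3ccccc3n2)c1` has not been measured. It arises from compound 3 by nitro in place of bromo on an aromatic carbon. This is the same kind of change as that from compound 1 to compound 2, but the place is not identical: in the earlier pair the group sits para to a large group, here it sits meta to a large group.

The expected step is a 1.3-fold higher number from compound 3 to compound 4 (0.11 log units; within the scatter) in this assay, resting on the within-scatter step a 1.5-fold higher number from compound 1 to compound 2 (0.16 log units; within the scatter) seen on the other core. Compound 4 is therefore estimated at 25000 nM, with a range from 10000 nM to 60000 nM.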

Compound 4, half-maximal inhibitory concentration: > 50000 nM
Compound 4 was reported as a limit (the forecaster's own chance of this, stated with the estimate: 15%); middle value at least 2.0-fold (0.30 log units) away from the limit.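

In this assay, the change of bromo to nitro gives an at least 2.5-fold higher number from compound 3 to compound 4 (0.41 log units; beyond the scatter), which stands beyond the scatter, whereas on the core of compound 1 the same change gives a 1.5-fold higher number from compound 1 to compound 2 (0.16 log units; within the scatter). On these data alone, compound 4 gives > 50000 nM, which is a limit of the assay and not a number, so the true size of the step on this core stays unknown: the limit of > 50000 nM in this assay, at which 1 of the 4 values shown sits. The pairs therefore show that the change can cost activity on the core of compound 3, but they do not show that its size carries over between the cores or that it differs between them, and the group also sits in a different place in the two pairs: the same change on two cores in this assay, a 1.5-fold higher number (0.16 log units; within the scatter) from compound 1 to compound 2 and an at least 2.5-fold higher number (0.41 log units; beyond the scatter) from compound 3 to compound 4; the limit leaves it open whether they differ.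

The compounds shown leave open how far the step on the core of compound 3 actually reaches. They also leave open how an amine or a carboxylic acid in place of the bromo would read on either core.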